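The source may hold more compounds than are shown below. What is called first, only, known or untested is meant among the compounds shown, and "the series" means these compounds.

Measured in an ADME assay on NCI/ADR-RES cells (Homo sapiens) for inhibition, read by MTT assay, with a stated time of 48 h; on this read-out lower numbers stand for stronger inhibition and higher numbers for weaker inhibition:
- compound 1 `CC(=O)O[C@@H]1C[C@@H](OC(=O)c2ccccc2)/C(C)=C/[C@H]2[C@@H](OC(=O)c3ccccc3)[C@@H](C)[C@H](O)[C@]2(OC(C)=O)[C@H](O)[C@](C)(O)/C=C/C1(C)C`: > 150000 nM
- compound 2 `CC(=O)O[C@@H]1C[C@@H](OC(=O)c2ccccc2)/C(C)=C/[C@H]2[C@@H](OC(=O)c3ccccc3)[C@@H](C)[C@H](OS(=O)(=O)c3ccc(C)cc3)[C@]2(OC(C)=O)[C@H](O)[C@](C)(O)/C=C/C1(C)C`: > 150000 nM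
- compound 3 `CC(=O)O[C@@H]1C[C@@H](OC(=O)c2ccccc2)/C(C)=C/[C@H]2[C@@H](OC(=O)c3ccccc3)[C@@H](C)[C@H](OC(=O)c3ccco3)[C@]2(OC(C)=O)[C@H](O)[C@](C)(O)/C=C/C1(C)C`: > 150000 nM

Each of these values is a limit of the assay and not a number. Compound 3 shares (the limit of > 150000 nM in this assay, at which 3 of the 3 values shown sit).

Next comes compound 4 `CC(=O)O[C@@H]1C[C@@H](OC(=O)c2ccccc2)/C(C)=C/[C@H]2[C@@H](OC(=O)c3ccccc3)[C@@H](C)[C@H](OC(=O)c3cccs3)[C@]2(OC(C)=O)[C@H](O)[C@](C)(O)/C=C/C1(C)C`, with thiophen-2-yl in place of furan-2-yl on a carbonyl carbon.

Within the data shown here, three measured steps bear on this only loosely: a step that the two limits leave unreadable from compound 1 to compound 2, a step that the two limits leave unreadable from compound 1 to compound 3 and a step that the two limits leave unreadable from compound 2 to compound 3. None gives a size, so the series offers no measured scale for this change. A further limit is expected, with no change beyond the scatter.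

The expected step is a step that the limit leaves unreadable from compound 3 to compound 4. The estimate for compound 4 is 180000 nM, with an expected range of 90000 nM to 350000 nM.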

Compound 4, half-maximal inhibitory concentration: > 150000 nM
Compound 4: no number, only a limit; the forecaster's own chance of this, stated with the estimate: 85%; the middle value is on the limit's open side.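

The result for compound 4 in this assay is a limit, so no step from compound 1, compound 2 or compound 3 to compound 4 can be read: the limit of > 150000 nM in this assay, at which 4 of the 4 values shown sit.

The compounds shown leave open whether any of these groups on the oxygen changes inhibition at all.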